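Adding a Methyl Group to Compound 3: An Expectation

The compounds below may be only part of what the source reports. "The series", "measured", "known", "first", "only" and "open" are said of these compounds alone.

Compound 1, `NC(=O)c1nn(C2O[C@H](CO)[C@@H](O)[C@H]2O)cc1Br`, gives in a functional assay on Raji cells (Homo sapiens) (on this read-out higher numbers stand for weaker inhibition and lower numbers for stronger inhibition), only a limit, > 1550 uM.
Compound 2, `Cc1c([N+](=O)[O-])c(C(N)=O)nn1C1O[C@H](CO)[C@@H](O)[C@H]1O`, gives in this assay only a limit, > 1650 uM.
Compound 3, `NC(=O)c1nn(C2O[C@H](CO)[C@@H](O)[C@H]2O)cc1N`, gives in this assay 1280 uM.

Going by the values given here, compound 3 thus holds the only actual number among the three; the values of compound 1 and compound 2 are limits of the assay, not numbers. Among the compounds with values here, the one measured step, an at least 1.2-fold lower number from compound 1 to compound 3 (0.08 log units; that floor lies within the scatter), swaps bromo for amino, and its floor lies within the scatter, so it carries little information about what follows.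

Compound 4, `Cc1c(N)c(C(N)=O)nn1C1O[C@H](CO)[C@@H](O)[C@H]1O`, differs from compound 3 by methyl in place of hydrogen on an aromatic carbon. Within the data shown here, no measured step puts a methyl in place of hydrogen anywhere in this set, so nothing in hand points up or down. The expected step is therefore a 1.0-fold higher number from compound 3 to compound 4 (0.01 log units; within the scatter), meaning no change beyond the scatter. Compound 4 is expected to give 1300 uM in this assay, between 600 uM and 3000 uM. Because compound 3 sits close to the limit of > 1550 uM in this assay, at which 1 of the 3 values shown sits, and (the limit of > 1650 uM in this assay, at which 1 of the 3 values shown sits), a limit rather than a number for compound 4 would not be surprising.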

Compound 4, concentration for 50% inhibition: > 1840 uM
Compound 4: only a limit was reported (the forecaster's own chance of this, stated with the estimate: 40%); middle value at least 1.4-fold (0.15 log units) away from the limit.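

In this assay, methyl in place of hydrogen, on the aromatic carbon next to the ring nitrogen, gives the first step seen at this position: an at least 1.4-fold higher number from compound 3 to compound 4 (0.15 log units; that floor lies within the scatter). Because compound 4 gives only a limit, this step is a floor, so it shows no stronger inhibition from the methyl but cannot prove a real loss, and the true distance could be larger. The step from compound 2 to compound 4 cannot be read, since both values are limits, and compound 4 adds a limit of its own: the limit of > 1840 uM in this assay, at which 1 of the 4 values shown sits.

On these data alone, how a longer chain such as ethyl, or a hydroxymethyl group, would behave on this carbon stays open. Also open, as far as these compounds go, is whether methyl here would give a readable number with bromo in place of the amino group.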